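Adding a Second Amino Acid Ester to Compound 2

The source may hold more compounds than are shown below. What is called first, only, known or untested is meant among the compounds shown, and "the series" means these compounds.

Measured compounds:
Compound 1, `N[C@@H](CCC(=O)OC[C@H]1O[C@@H](n2cc(F)c(=O)[nH]c2=O)C[C@@H]1OC(=O)CC[C@H](N)C(=O)O)C(=O)O`: 3300000 nM
Compound 2, `N[C@@H](CC(=O)OC[C@H]1O[C@@H](n2cc(F)c(=O)[nH]c2=O)C[C@@H]1O)C(=O)O`: 3600000 nM

Both compounds were tested in a functional assay on MIA PaCa-2 cells (Homo sapiens) for inhibition, read by MTT assay, with a stated time of 24 h; on this read-out higher numbers stand for weaker inhibition of growth and lower numbers for stronger inhibition of growth. Compound 1 gives 3300000 nM, and compound 2 gives 3600000 nM. Compound 2 has the higher of the two numbers, but its gap to compound 1 lies within the usual scatter of this assay, so the two cannot be told apart on these data.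

Compound 3, `N[C@@H](CC(=O)OC[C@H]1O[C@@H](n2cc(F)c(=O)[nH]c2=O)C[C@@H]1OC(=O)C[C@H](N)C(=O)O)C(=O)O`, differs from compound 2 in a single place: (2-amino-2-carboxyethyl)carbonyl in place of hydrogen on an oxygen on a saturated carbon. Going by the values given here, no pair of measured compounds here is separated by one change, so the step cannot be read from a directly comparable pair. What can be seen is that compound 1, which also carries an amino acid ester on each of the two oxygens, sits close to compound 2 in this assay. From that, the step from compound 2 to compound 3 is expected to be small, with no direction beyond the scatter, as a 1.1-fold lower number from compound 2 to compound 3 (0.05 log units; within the scatter) expresses. Compound 3 is therefore estimated at 3200000 nM, within a range of 1500000 nM to 7000000 nM.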

Compound 3, concentration for 50% growth inhibition: 2000000 nM
The estimate for compound 3 lay 1.6-fold (0.20 log units) above the measured number, within the range that was stated.
By their numbers in this assay, from the lowest: compounds 3, 1 and 2 (each within the scatter of the next).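

Going by these compounds alone, the hydroxy on the saturated ring carbon of compound 2 can now be judged directly, as this is the first step here read from a pair of compounds that differ in one place. In this assay, putting (2-amino-2-carboxyethyl)carbonyl in place of the hydrogen on that oxygen gives a 1.8-fold lower number from compound 2 to compound 3 (0.26 log units; within the scatter), so even a whole second amino acid ester at this position produces no difference that can be told from the ordinary spread of repeated measurements. No measurement shown here offers an explanation for this result.

As far as these compounds go, it remains open whether a plain acetyl ester, with neither an amine nor a carboxylic acid on it, or a methyl ether on this oxygen would give a step beyond the scatter. Steps involving compound 1 cannot be read, since it differs from compound 2 and compound 3 in more than one place, so the effect of the longer chain in its amino acid esters stays unresolved.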